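The compounds below may be only part of what the source reports. "The series", "measured", "known", "first", "only" and "open" are said of these compounds alone.

Compound 1 `CC1(C)S[C@@H]2/C(=C\C(=O)c3cc(C(F)(F)F)cc(C(F)(F)F)c3)C(=O)N2[C@H]1C(=O)OC(c1ccccc1)c1ccccc1`: 39200 nM
Compound 2 `CC1(C)S[C@@H]2C/C(=C\C(=O)c3ccccc3)C(=O)N2[C@H]1C(=O)OC(c1ccccc1)c1ccccc1`: > 100000 nM
Compound 3 `CC1(C)S[C@@H]2/C(=C\C(=O)c3ccc(F)cc3)C(=O)N2[C@H]1C(=O)OC(c1ccccc1)c1ccccc1`: 17800 nM

Of the compounds shown here, three sharing one core have been tested in a functional assay on A-375 cells (Homo sapiens) for cytotoxicity, read by MTT assay, with a stated time of 48 h; on this read-out higher numbers stand for weaker inhibition and lower numbers for stronger inhibition. Compound 1 gives 39200 nM. Compound 2 reaches only the limit of this assay, > 100000 nM, so for it no number is known. Compound 3 gives 17800 nM, the lowest of the two numbers shown; its nearest neighbour is compound 1, whose number sits higher by a gap beyond the usual scatter. No pair among these compounds differs in one place only, so no single measured step is available to lean on.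

Compound 4 `CC1(C)S[C@@H]2/C(=C\C(=O)OCc3ccccc3)C(=O)N2[C@H]1C(=O)OC(c1ccccc1)c1ccccc1` has not yet been measured. It differs from compound 3 in one place: benzyloxy in place of 4-fluorophenyl on a carbonyl carbon. Both groups carry one six-membered aromatic ring of carbon only, but the benzyloxy group brings one oxygen and one hydrogen-bond acceptor where the 4-fluorophenyl brought none. Because compound 3 itself sits at 17800 nM, the whole series is weak, and the change is expected to cost a little more. The step from compound 3 to compound 4 is expected to be a modest loss, a 2.0-fold higher number from compound 3 to compound 4 (0.29 log units; within the scatter), possibly beyond the scatter. Compound 4 is therefore estimated at 35000 nM in this assay, with a range from 12000 nM to 100000 nM, and a real chance that only a limit is returned.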

Compound 4, half-maximal inhibitory concentration: 7100 nM
Compound 4: the middle estimate sits 4.9-fold (0.69 log units) above what was measured; measured number below the stated range.
By their numbers in this assay, from the lowest: compound 4; then compound 3; then compound 1. At a limit, above all of these: compound 2.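

In this assay, for the compounds shown here, putting benzyloxy in place of 4-fluorophenyl on a carbonyl carbon gives a 2.5-fold lower number from compound 3 to compound 4 (0.40 log units; beyond the scatter), a modest step and the first single change that can be read in this set. It shows that the group on this carbonyl carbon, whose other neighbour is the double-bonded chain carbon, need not be 4-fluorophenyl: benzyloxy, which carries a hydrogen-bond acceptor and no fluorine, is accepted here, and the number falls rather than rises. Nothing measured here tells which part of the swap accounts for the step, whether the oxygen that enters, the extra carbon or the fluorine that leaves.

The compounds shown leave open whether that oxygen matters at all: a benzylamino group, with a nitrogen amine in its place, or a longer chain such as phenethyloxy on the same carbonyl carbon, would pull these parts apart. A single pair also leaves open whether the step holds for other groups at this carbonyl carbon, such as a plain methoxy or a carboxylic acid.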